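Swapping Methoxy for Chloro: From Compound 2 to Compound 4

This account rests on a few compounds, and the source may have more. Where it says the series, first, only, none or still open, it means among the compounds named here.

Compound 1 `Cc1ccc(S(=O)(=O)NCc2ccc(CNC(=O)c3ccccc3)cc2)cc1` gives > 1000 nM in an assay on MDA-MB-231 cells for binding affinity to C-X-C chemokine receptor type 4 (Homo sapiens), read by immunofluorescence and microscopy, with stated times of 10 min and 30 min (on this read-out lower numbers stand for an effect already at smaller amounts and higher numbers for an effect only at larger amounts of compound), which is a limit of the assay and not a number.
Compound 2 `COc1ccc(C(=O)NCc2ccc(CNS(=O)(=O)c3ccccc3)cc2)cc1` gives 1000 nM in this assay.
Compound 3 `Cc1ccc(S(=O)(=O)NCc2ccc(CNC(=O)c3ccncc3)cc2)cc1` gives 10 nM in this assay.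

Compound 2 stands at the highest of the two numbers shown; compound 3 reads far lower, beyond the scatter, while compound 1 sits at the limit. Compound 4 `O=C(NCc1ccc(CNS(=O)(=O)c2ccccc2)cc1)c1ccc(Cl)cc1` has not yet been measured. It differs from compound 2 in one place: chloro in place of methoxy on an aromatic carbon.

Among the compounds with values here, only one measured step exists between compounds that differ in a single place, and it is an at least 100-fold lower number from compound 1 to compound 3 (2.00 log units; beyond the scatter). That step changes the ring attached to the carbonyl carbon, not a substituent on an aromatic carbon, so it says nothing direct about trading methoxy for chloro. Within the data shown here, compound 1 and compound 2 differ in two places at once, so their values give no clean step either. Among the measured compounds shown here, with no comparable measured step to lean on, the change from compound 2 to compound 4 is expected to give no step beyond the scatter in this assay: no change at the digits printed from compound 2 to compound 4 (within the scatter).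

Compound 4 is therefore estimated at 1000 nM in this assay, with a range from 300 nM to 3000 nM.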

Compound 4, effective concentration (reported as EC, without a stated level of effect): 100 nM
Estimate against measurement, compound 4: 10-fold (1.00 log units) above; measured number outside the range, below it.
By their numbers in this assay, from the lowest: compound 3; then compound 4; then compound 2.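

Within the data shown here, until now the only readable step in this assay replaced the whole ring on the carbonyl carbon, whereas this change keeps the ring and alters only the group on one aromatic carbon, para to a large group, and still gives a 10-fold lower number from compound 2 to compound 4 (1.00 log units; beyond the scatter). This end of the molecule therefore responds to a small substituent swap as well as to a change of ring. The swap takes away the methoxy with its hydrogen-bond acceptor and puts a chloro in its place, but no measurement given here shows why the number falls.

Among these compounds, it remains open whether this result is particular to chloro or whether a bromo, a methyl, an amine or a carboxylic acid in the same place would read similarly, higher or lower, since only two groups at this position can be compared. Going by these compounds, it also remains open whether the same swap from 4-methoxyphenyl to 4-chlorophenyl would shift the number by a similar amount on the core of compound 1, as a single step says nothing about how far it carries to other compounds.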